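This account rests on a few compounds, and the source may have more. Where it says the series, first, only, none or still open, it means among the compounds named here.

Measured compounds:
Compound 1 `COc1cc(Cl)ccc1C(=S)Nc1ccc(Br)cc1O` — 3880 nM
Compound 2 `COc1cc(Cl)ccc1C(=S)Nc1cc(Br)ccc1O` — 6530 nM
Compound 3 `COc1cc(Cl)ccc1C(=S)Nc1ccc(C(F)(F)F)cc1O` — 3140 nM

The three measured compounds were tested in a functional assay on HepG2 cells (Homo sapiens) for cytotoxicity, with a stated time of 24 h; a lower number here means a stronger inhibitor, a higher number a weaker inhibitor. Compound 1 gives 3880 nM and compound 3 gives 3140 nM in this assay; the change between them is trifluoromethyl in place of bromo on an aromatic carbon, and the step of a 1.2-fold lower number from compound 1 to compound 3 (0.09 log units; within the scatter) is small. Compound 2, with 6530 nM in this assay, has the same atoms as compound 1 joined differently; the difference between the two cores is not broken down here. Its number sits within the scatter of compound 1 and is higher than that of compound 3.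

Compound 4 `COc1cc(Cl)ccc1C(=S)Nc1cc(C(F)(F)F)ccc1O` has not yet been measured in this assay. It differs from compound 2 by trifluoromethyl in place of bromo on an aromatic carbon. Going by the values given here, this is the same kind of change as the one from compound 1 to compound 3, but not the same: in compound 4 the trifluoromethyl stands meta to a large group and para to a hydroxy group, whereas in compound 3 it stands meta to a hydroxy group and para to a large group.

The expectation for compound 4 rests on the step from compound 1 to compound 3, which was a 1.2-fold lower number from compound 1 to compound 3 (0.09 log units; within the scatter) and within the scatter; a step of similar size from compound 2 is therefore expected, a 1.2-fold lower number from compound 2 to compound 4 (0.08 log units; within the scatter). Compound 4 is estimated at 5400 nM in this assay, expected to fall between 2700 nM and 11000 nM.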

Compound 4, half-maximal inhibitory concentration: 5740 nM
Beside the measured number, compound 4's estimate is 1.1-fold (0.03 log units) below it; low and high end bracket the measured number.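

In this assay the exchange of bromo for trifluoromethyl on the core of compound 2 gives a 1.1-fold lower number from compound 2 to compound 4 (0.06 log units; within the scatter) and so, like the same exchange on the core of compound 1, yields a step that cannot be told from the scatter. Set side by side, the two exchanges agree: the same change on two cores in this assay, a 1.2-fold lower number (0.09 log units; within the scatter) from compound 1 to compound 3 and a 1.1-fold lower number (0.06 log units; within the scatter) from compound 2 to compound 4, 1.1-fold (0.04 log units) apart, within the scatter of two such steps. Across these four compounds the change therefore carries from one core to the other as a step too small to read, but this shows only that neither core responds measurably to this one exchange in this one test, and it does not show that the agreement would hold on other cores, in other cell assays or for a change that gave a larger step on its first core.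

The compounds shown leave open whether any other group at this place, such as a nitrile, a methyl or an amine, would produce a step beyond the scatter. They also leave open what the hydroxy group present in all four compounds contributes, and whether a methoxy group or an amine in its place would alter the numbers.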